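This account rests on a few compounds, and the source may have more. Where it says the series, first, only, none or still open, it means among the compounds named here.

In a functional assay on A549 cells (Homo sapiens) for inhibition, with a stated time of 72 h (on this read-out lower numbers stand for stronger inhibition and higher numbers for weaker inhibition), compound 1 `O=C(Nc1ccccc1)Nc1nc(NC2CC2)cc(Sc2c[nH]c3ccccc23)n1` gives > 50000 nM, which is a limit of the assay and not a number. Two relatives differ from it in the group that replaces cyclopropylamino on the shared core. In the same assay, compound 2 `O=C(Nc1ccccc1)Nc1nc(Sc2c[nH]c3ccccc23)cc(N2CCCC2)n1` gives 21200 nM, and compound 3 `O=C(Nc1ccccc1)Nc1nc(Nc2ccc(Cl)cc2)cc(Sc2c[nH]c3ccccc23)n1` gives 48400 nM. Pyrrolidin-1-yl brings an at least 2.3-fold lower number from compound 1 to compound 2 (0.37 log units; beyond the scatter), the swap to 4-chlorophenyl on the nitrogen brings an at least 1.0-fold lower number from compound 1 to compound 3 (0.01 log units; that floor lies within the scatter), and the comparison of the last two shows a 2.3-fold higher number from compound 2 to compound 3 (0.36 log units; beyond the scatter).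

Compound 4 `Cc1cc(Cl)ccc1NC(=O)Nc1nc(NC2CC2)cc(Sc2c[nH]c3ccccc23)n1` keeps the cyclopropylamino group of compound 1 and changes a different place: 4-chloro-2-methylphenyl in place of phenyl on an amide-type nitrogen. Among the measured compounds shown here, no measured step touches this place, so the three steps bear on it only indirectly, as a guide to the size of change seen on this core, and they are modest at most. In this assay, a modest move towards a lower number is therefore expected, though compound 4 may also stay at the limit. The expected change is an at least 2.2-fold lower number from compound 1 to compound 4 (0.35 log units; beyond the scatter). For compound 4 the estimate is 22000 nM, with an expected range from 6000 nM to 60000 nM.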

Compound 4, half-maximal inhibitory concentration: 31500 nM
Compound 4: middle estimate off by 1.4-fold (0.16 log units), on the low side; the measured number falls inside the stated range.
By their numbers in this assay, from the lowest: compounds 2, 4 and 3 (each within the scatter of the next, the first and the last beyond it). At a limit, above all of these: compound 1.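

Changing phenyl to 4-chloro-2-methylphenyl on an amide-type nitrogen brings an at least 1.5-fold lower number from compound 1 to compound 4 (0.20 log units; that floor lies within the scatter) in this assay. Compound 4 thus shows that a change at this place, away from the group varied in compounds 2 and 3, can give a measured number while the cyclopropylamino group stays in place. How large the step is cannot be fixed, and the printed floor alone does not establish a change beyond the scatter, because compound 1 has only a limit and not a number: the limit of > 50000 nM in this assay, at which 1 of the 4 values shown sits.

The compounds shown leave open whether the chloro group, the methyl group or the two together account for the number of compound 4, since neither appears alone on the phenyl ring. They also leave open how a methoxy group or a carboxylic acid on that ring would read in this assay, and whether 4-chloro-2-methylphenyl would give a different number with the pyrrolidin-1-yl group of compound 2 on the shared core.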